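Tolerated concentration across the side chains of the series

The compounds below may be only part of what the source reports. "The series", "measured", "known", "first", "only" and "open" are said of these compounds alone.

Measured in an ADME assay on HOS cells (Homo sapiens) for cytotoxicity, read by luminescence and ATP content, with a stated time of 48 h; a lower number here means that less compound is tolerated, a higher number that more compound is tolerated:
- compound 1 `CN(C)CCCc1cnc2c(c1)c(N)c(C(=O)NCc1ccc(F)cc1F)c(=O)n2O`: 5000 nM
- compound 2 `CN(C)C(=O)CCc1cnc2c(c1)c(N)c(C(=O)NCc1ccc(F)cc1F)c(=O)n2O`: > 250000 nM (a limit)
- compound 3 `CN(C)C(=O)/C=C/c1cnc2c(c1)c(N)c(C(=O)NCc1ccc(F)cc1F)c(=O)n2O`: > 250000 nM (a limit)

Compound 3 stands at a limit, > 250000 nM, and not at a number. This is the limit of > 250000 nM in this assay, at which 2 of the 3 values shown sit.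

Compound 4 `COC(=O)CCc1cnc2c(c1)c(N)c(C(=O)NCc1ccc(F)cc1F)c(=O)n2O` carries 2-(methoxycarbonyl)ethyl in place of 2-(dimethylcarbamoyl)ethenyl on an aromatic carbon.

Two large measured steps, both beyond the scatter, bear on this change: an at least 50-fold higher number from compound 1 to compound 2 (1.69 log units; beyond the scatter), and an at least 50-fold higher number from compound 1 to compound 3 (1.69 log units; beyond the scatter). Both move away from the 3-(dimethylamino)propyl of compound 1, a group that compound 4 also lacks. The third step, a step that the two limits leave unreadable from compound 2 to compound 3, cannot be read, so the loss of the ethenyl link remains unsized. Within the data shown here, no measured step exchanges dimethylcarbamoyl for methoxycarbonyl. Compound 4 is therefore expected to stay in the high range of this assay, at the limit or somewhat lower, and well short of the large steps away from compound 1.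

The estimated step is an at least 2.0-fold lower number from compound 3 to compound 4 (0.31 log units; beyond the scatter).

For compound 4 the estimate is 120000 nM, with an expected range of 25000 nM to 250000 nM.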

Compound 4, half-maximal cytotoxic concentration: > 250000 nM
Compound 4: a limit, no number; the forecaster's own chance of this, stated with the estimate: 55%; middle value at least 2.0-fold (0.31 log units) away from the limit.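

In this assay compound 4 gives > 250000 nM, which is a limit and not a number. The high range at this position therefore does not depend on dimethylcarbamoyl, and the large step away from the 3-(dimethylamino)propyl chain recurs with 2-(methoxycarbonyl)ethyl, at an at least 50-fold higher number from compound 1 to compound 4 (1.69 log units; beyond the scatter). The steps among compound 2, compound 3 and compound 4 cannot be read, so the ester and the two amides cannot be ordered, and the series now piles up at the top of the scale: the limit of > 250000 nM in this assay, at which 3 of the 4 values shown sit.

As far as these compounds go, how far these three compounds lie beyond the limit stays open. Also open, from the compounds shown here alone, is whether the lower number of compound 1 goes with its terminal dimethylamino group specifically, a question that a primary amine or a carboxylic acid on the same chain, or a longer chain ending in methoxycarbonyl, would bear on.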